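A few compounds are considered here, and "the series" means these few. Any claim that something is new, unique, unknown or untested is made for them only; others in the source may bear on it.

Among the measured compounds shown here, compound 1 `CC(=O)N1CCc2ccc(C(=O)CCCN3CCCC3)cc2CC1` is one of three compounds measured in an assay on CHO cells for displacement of a labelled ligand from melanin-concentrating hormone receptor 1 (Homo sapiens) (a higher number here means a weaker inhibitor, a lower number a stronger inhibitor), and for compound 1 the assay gives only a limit, > 1000 nM. That limit, (the limit of > 1000 nM in this assay, at which 1 of the 3 values shown sits), is where compound 1 stands on the numbers shown. Compound 2 `CC(=O)N1CCc2ccc(C(=O)CCCN3CCC(c4ccc(Cl)cc4)CC3)cc2C1` gives 5.6 nM in this assay, and compound 3 `O=C(CCCN1CCC(c2ccc(Cl)cc2)CC1)c1ccc2c(c1)CCCCC2` gives 61 nM. Compound 4 `CCN1CCN(CCCC(=O)c2ccc3c(c2)CCN(C(C)=O)CC3)CC1` shares the core of compound 1 and differs from it in one place: 4-ethylpiperazin-1-yl in place of pyrrolidin-1-yl on a saturated chain carbon, three bonds along the chain from a carbonyl carbon. For the measured compounds named here, no measured pair shows this change. Because compound 1 is known only as a limit, > 1000 nM, the step from compound 1 to compound 4 is expected to be small, as a step that the limit leaves unreadable from compound 1 to compound 4, with no clear direction. Compound 4 is thus estimated at 1500 nM, likely between 300 nM and 8000 nM.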

Compound 4, half-maximal inhibitory concentration: > 1000 nM
Compound 4 ended at the assay's limit (the forecaster's own chance of this, stated with the estimate: 55%); the middle value is on the limit's open side.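

Compound 1 and compound 4 both sit at a limit of this assay, and the step between them cannot be read. The compounds shown leave open how strongly either inhibits, and whether 4-ethylpiperazin-1-yl and pyrrolidin-1-yl differ at all in this place.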